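From Trifluoromethyl to Diethylamino: Expecting the Next Number

The compounds below may be only part of what the source reports. "The series", "measured", "known", "first", "only" and "open" are said of these compounds alone.

Compound 1, `COc1cccc(OC)c1C(=O)Nc1nnc(-c2ccc(Cl)cc2)s1`: 58.9 nM
Compound 2, `COc1cccc(OC)c1C(=O)Nc1nnc(-c2ccccc2)s1`: 2950 nM
Compound 3, `COc1cccc(OC)c1C(=O)Nc1nnc(-c2ccc(C(F)(F)F)cc2)s1`: 49 nM

Three compounds share one core and differ only in the group on a six-membered aromatic ring of carbon only. In a functional assay on the whole organism (integument) for inhibition, with Chilo suppressalis as the target, read by scintillation counting, with a stated time of 72 h (a higher number here means a weaker inhibitor, a lower number a stronger inhibitor), compound 3 gives the lowest number of the three. Compound 1 cannot be told apart from it, since a 1.2-fold lower number from compound 1 to compound 3 (0.08 log units; within the scatter). Compound 2 stands far away: a 60-fold lower number from compound 2 to compound 3 (1.78 log units; beyond the scatter).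

Compound 4, `CCN(CC)c1ccc(-c2nnc(NC(=O)c3c(OC)cccc3OC)s2)cc1`, carries a new group at the same place: diethylamino in place of trifluoromethyl on an aromatic carbon. Going by the values given here, two measured steps bear on this. The steps of a 50-fold higher number from compound 1 to compound 2 (1.70 log units; beyond the scatter) and a 60-fold lower number from compound 2 to compound 3 (1.78 log units; beyond the scatter) show that a bare hydrogen at this place gives a much weaker inhibitor than either chloro or trifluoromethyl, while a 1.2-fold lower number from compound 1 to compound 3 (0.08 log units; within the scatter) shows that two different groups there give numbers alike within the scatter. Among the compounds with values here, no measured compound carries anything resembling diethylamino, so its effect is unknown from these data. A group is present rather than absent, which speaks for staying closer to compound 3 than to compound 2, but with wide uncertainty. The expected step is a 5.1-fold higher number from compound 3 to compound 4 (0.71 log units; beyond the scatter). Compound 4 is thus estimated at 250 nM, with a range from 40 nM to 2500 nM.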

Compound 4, half-maximal inhibitory concentration: 741 nM
Beside the measured number, compound 4's estimate is 3.0-fold (0.47 log units) below it, and the stated range covers the measured number.
By their numbers in this assay, from the lowest: compounds 3 and 1 (each within the scatter of the next); then compound 4; then compound 2.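

In this assay, having a group at this place on the ring is not enough on its own to match the best compounds. Diethylamino gives a 15-fold higher number from compound 3 to compound 4 (1.18 log units; beyond the scatter) and a 13-fold higher number from compound 1 to compound 4 (1.10 log units; beyond the scatter), so it falls well short of both trifluoromethyl and chloro, even though those two cannot be told apart from each other. It still improves on bare hydrogen, with a 4.0-fold lower number from compound 2 to compound 4 (0.60 log units; beyond the scatter), so the four compounds now fall into three tiers: chloro and trifluoromethyl together, then diethylamino, then hydrogen, and nothing available here explains why diethylamino sits in the middle tier.

The compounds shown cannot separate the contribution of the nitrogen from that of the two ethyl chains, since both enter together as one group. Dimethylamino or a plain amine, set against an all-carbon chain such as butyl at this same place, would pull those two parts apart, and a halogen such as fluoro or bromo would show whether chloro's level extends to its neighbours in that family.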